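A Fluoro-to-Methoxy Swap on the Aniline Ring

The source may report more compounds than this note shows. Statements on the series, on what has been measured and on what is new or still open speak of the compounds shown alone.

Compound 1 `O=C(/C=C\Nc1ccc(F)cc1)c1cn(-c2ccccc2)nc1-c1ccccc1`: 7980 nM
Compound 2 `O=C(/C=C\Nc1ccc(F)cc1)c1cn(-c2ccccc2)nc1-c1ccc(F)cc1`: 7900 nM

Among the measured compounds shown here, in a functional assay on PC-3 cells (Homo sapiens) for antiproliferative activity, read by MTT assay, with a stated time of 48 h (on this read-out higher numbers stand for weaker inhibition and lower numbers for stronger inhibition), compound 2 gives 7900 nM, and it stands level with compound 1, the only other measured compound, within the usual scatter. Compound 3 `COc1ccc(N/C=C\C(=O)c2cn(-c3ccccc3)nc2-c2ccc(F)cc2)cc1` has methoxy in place of fluoro on an aromatic carbon, para to a large group: methoxy in place of fluoro on an aromatic carbon. One measured step offers guidance: a 1.0-fold lower number from compound 1 to compound 2 (0.00 log units; within the scatter). It put fluoro in place of hydrogen on an aromatic carbon, though not on the carbon that changes now, and it stayed within the scatter. For the measured compounds named here, no measured pair exchanges fluoro for methoxy, so the evidence is thin and no direction can be favoured. The expected change, a 1.1-fold lower number from compound 2 to compound 3 (0.05 log units; within the scatter), is therefore no step beyond the scatter. For compound 3 the estimated value is 7000 nM, with an expected range from 2800 nM to 18000 nM.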

Compound 3, half-maximal inhibitory concentration: 4600 nM
The estimate for compound 3 lay 1.5-fold (0.18 log units) above the measured number; the range from low to high includes it.
By their numbers in this assay, from the lowest: compounds 3, 2 and 1 (each within the scatter of the next).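

Among the compounds shown here, the earlier pair changed a different aromatic carbon, so this is the only measured change at the (4-fluorophenyl)amino group. Replacing it with (4-methoxyphenyl)amino gives a 1.7-fold lower number from compound 2 to compound 3 (0.23 log units; within the scatter) in this assay, which shows that this position accepts methoxy, a group with a hydrogen-bond acceptor where fluoro has none, without a step beyond the scatter. The data offer no measured property that could explain this result.

On these data alone, whether a different group at this carbon, such as an amine, a carboxylic acid or a longer chain like butoxy, would give a step beyond the scatter remains open. As far as these compounds go, it is also open whether methoxy would behave the same way in the core of compound 1, which has hydrogen in place of fluoro on its other aromatic carbon.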